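Saturating the Linker: Compound 1 to Compound 4

This account rests on a few compounds, and the source may have more. Where it says the series, first, only, none or still open, it means among the compounds named here.

The measured compounds and their values:
- compound 1 `CCOC(=O)CCO/N=C(/c1ccc(OC)c(OC)c1OC)c1cccc2ccccc12`: > 20000 nM
- compound 2 `COc1ccc(C(c2ccc(OC(C)CN(C)C)cc2)c2cccc3ccccc23)c(OC)c1OC`: 13100 nM
- compound 3 `COc1ccc(C(O)(Cc2ccc(C)cc2)c2cccc3ccccc23)c(OC)c1OC`: > 20000 nM

Of the compounds shown here, three sharing a core have been tested in a functional assay on MCF7 cells (Homo sapiens) for inhibition, read by sulforhodamine B assay, with a stated time of 48 h; a lower number here means a stronger inhibitor, a higher number a weaker inhibitor. Compound 1 gives only a limit of the assay, > 20000 nM, and no number. Compound 3 likewise reaches only a limit in this assay, > 20000 nM. Among the measured compounds shown here, compound 2 is the single compound with a numerical value, 13100 nM, and it is weak. Compound 1 therefore stands at the upper edge of what this assay reports, a position shared with compound 3 according to the limit of > 20000 nM in this assay, at which 2 of the 3 values shown sit.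

Compound 4 `CCOC(=O)/C=C/CO/N=C(/c1ccc(OC)c(OC)c1OC)c1cccc2ccccc12` is not yet measured. It differs from compound 1 in one place: 2-(ethoxycarbonyl)ethenyl in place of (ethoxycarbonyl)methyl on a saturated chain carbon bound to an oxygen on an unsaturated carbon. The change adds one carbon and one double bond to a side chain while keeping the ester and the oxime linkage intact.

For the measured compounds named here, no step between measured compounds exists to calibrate this change, so the expectation for compound 4 is that its value stays within the scatter of compound 1, with a step that the limit leaves unreadable from compound 1 to compound 4 amounting to no real shift, and compound 4 is estimated at 25000 nM, between 10000 nM and 60000 nM, most likely again reported only as a limit.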

Compound 4, half-maximal inhibitory concentration: > 20000 nM
Compound 4: a limit, no number; the forecaster's own chance of this, stated with the estimate: 70%; the middle value does not contradict the limit.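

Among the compounds shown here, compound 1 and compound 4 both reach only a limit in this assay, and no step between them can be read: the limit of > 20000 nM in this assay, at which 3 of the 4 values shown sit.

The compounds shown leave open how far 2-(ethoxycarbonyl)ethenyl in place of (ethoxycarbonyl)methyl moves the value, as neither compound has a number.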